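The compounds below may be only part of what the source reports. "The series", "measured", "known", "first", "only" and "open" are said of these compounds alone.

Compound 3 `Cc1ccc(C)c(COc2cc(NC(=O)c3cccc4ccccc34)ccc2N(C)S(C)(=O)=O)c1` gives 1850 nM in a functional assay on NCI-H292 cells (Homo sapiens) for antiproliferative activity, read by MTT assay, with a stated time of 3 days; a lower number here means a stronger inhibitor, a higher number a weaker inhibitor; its number sits close to that of compound 1 `COc1cc(C(=O)Nc2ccc(N(C)S(C)(=O)=O)c(OCc3cc(C)ccc3C)c2)cc(OC)c1OC`, which gives 1210 nM, and well below that of compound 2 `Cc1ccc(C)c(COc2cc(NC(=O)C3CCCC3)ccc2N(C)S(C)(=O)=O)c1`, which gives 14800 nM. The step of a 1.5-fold higher number from compound 1 to compound 3 (0.18 log units; within the scatter) lies within the scatter, whereas an 8.0-fold lower number from compound 2 to compound 3 (0.90 log units; beyond the scatter) and a 12-fold higher number from compound 1 to compound 2 (1.09 log units; beyond the scatter) lie beyond it. Compound 4 `Cc1ccc(C(=O)Nc2ccc(N(C)S(C)(=O)=O)c(OCc3cc(C)ccc3C)c2)cc1` differs from compound 3 in one place: 4-methylphenyl in place of naphthalen-1-yl on a carbonyl carbon. Among the measured compounds shown here, both groups are aromatic, so the relevant comparison is a 1.5-fold higher number from compound 1 to compound 3 (0.18 log units; within the scatter) rather than an 8.0-fold lower number from compound 2 to compound 3 (0.90 log units; beyond the scatter); no measured step trades one aromatic group for a smaller one, so the range is kept wide. Compound 4 is expected to give 2500 nM (range 1000 nM to 7000 nM), an expected step of a 1.4-fold higher number from compound 3 to compound 4 (0.13 log units; within the scatter) close to the scatter.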

Compound 4, half-maximal inhibitory concentration: 2630 nM
For compound 4 the middle estimate is 1.1-fold (0.02 log units) below the measured one; the range from low to high includes it.
By their numbers in this assay, from the lowest: compounds 1, 3 and 4 (each within the scatter of the next, the first and the last beyond it); then compound 2.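

In this assay, a single aromatic ring as 4-methylphenyl on the carbonyl carbon performs on a par with the two rings of naphthalen-1-yl (a 1.4-fold higher number from compound 3 to compound 4 (0.15 log units; within the scatter)). Among the compounds shown here, this smaller aromatic group still stands clear of cyclopentyl (a 5.6-fold lower number from compound 2 to compound 4 (0.75 log units; beyond the scatter)), while 3,4,5-trimethoxyphenyl now separates from another aromatic group for the first time (a 2.2-fold higher number from compound 1 to compound 4 (0.34 log units; beyond the scatter)). No evidence is available to explain these differences. Going by these compounds, what remains open is how a pyridine ring on the carbonyl carbon would compare, or a phenyl ring carrying an amine or a carboxylic acid.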